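Methoxy removal on the shared core

The source may report more compounds than this note shows. Statements on the series, on what has been measured and on what is new or still open speak of the compounds shown alone.

Measured in an assay on membranes from brain for displacement of a labelled ligand from adenosine receptor A1 (Rattus norvegicus), read by radioligand binding; on this read-out higher numbers stand for weaker inhibition and lower numbers for stronger inhibition:
compound 1 `COc1cccc2c1C/C(=C\c1cccc(O)c1)C2=O` gives 41 nM;
compound 2 `COc1cc2c(cc1OC)C(=O)/C(=C/c1ccc(O)c(O)c1)C2` gives 4290 nM.

Compound 2 holds the highest of the two numbers in this assay; compound 1 sits at a far lower number, a gap beyond the scatter. Compound 3 `COc1ccc2c(c1)C/C(=C\c1ccc(O)c(O)c1)C2=O` differs from compound 2 in one place: hydrogen in place of methoxy on an aromatic carbon. Among the compounds with values here, no single-point step between measured compounds exists, so this change has no direct precedent. Compound 1, carrying a single methoxy, gives 41 nM and points toward a lower number for compound 3. The step is expected to be a decrease beyond the scatter, a 5.4-fold lower number from compound 2 to compound 3 (0.73 log units; beyond the scatter). Compound 3 is estimated at 800 nM, within 150 nM to 4000 nM.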

Compound 3, inhibition constant: 3280 nM
The estimate for compound 3 lay 4.1-fold (0.61 log units) below the measured number, and the stated range covers the measured number.
By their numbers in this assay, from the lowest: compound 1; then compounds 3 and 2 (each within the scatter of the next).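

In this assay, hydrogen in place of methoxy on this aromatic carbon gives a 1.3-fold lower number from compound 2 to compound 3 (0.12 log units; within the scatter). This single-place step shows that, with the other methoxy kept, losing this methoxy produces no change beyond the scatter. No measurement available here explains this result.

From the compounds shown here alone, whether an amine or a carboxylic acid at this position would leave the number equally unmoved remains open. Compound 1 differs from compound 2 and compound 3 in more than one place, so why compound 1 gives 41 nM cannot be read from this step.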